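The source may hold more compounds than are shown below. What is called first, only, known or untested is meant among the compounds shown, and "the series" means these compounds.

Notes on the series. Compound 1 `CC1=C(C(=O)OC(C)(C)C)C(c2ccsc2)NC(=O)N1` and compound 2 `CCC(CC)OC(=O)C1=C(C)NC(=O)NC1c1cccs1` have both been run in an assay on membranes from HeLa cells for displacement of a labelled ligand from adenosine receptor A3 (Homo sapiens), read by scintillation counting, with a stated time of 180 min, tested at 1 uM; on this read-out higher numbers stand for more inhibition at the one concentration tested (going by the name of the read-out) and lower numbers for less inhibition. In this assay compound 1 gives 1%, and in the same run compound 2 gives 1%. The two read-outs are level at the digits given and lie within the scatter of each other, so compound 2 stands with compound 1 at the floor of the range, showing essentially no displacement at the concentration tested.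

Compound 3 `CCC(CC)OC(=O)C1=C(C)NC(=O)NC1c1ccsc1` is the next member. It differs from compound 2 as follows: thiophen-3-yl in place of thiophen-2-yl on a saturated ring carbon. For the measured compounds named here, no step between two measured compounds covers a change of this kind, so the expectation rests on the two values alone. Both measured compounds sit at the floor, and the change keeps the same atoms joined differently; nothing here points in either direction. The step expected is a number 1 percentage points higher from compound 2 to compound 3 (within the scatter), that is nothing beyond the scatter. In this assay compound 3 is estimated at 2%, with a range from 0% to 12%.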

Compound 3, a percentage reported as inhibition, at one concentration (the size of the read-out at that concentration, not a potency): 6%
Beside the measured number, compound 3's estimate is 4 percentage points below it; the range from low to high includes it.
By their numbers in this assay, from the lowest: compounds 1, 2 and 3 (each within the scatter of the next).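

In this assay, moving the attachment point of the thiophene on the saturated ring carbon gives a number 5 percentage points higher from compound 2 to compound 3 (within the scatter), so at this position thiophen-3-yl and thiophen-2-yl are not separated at the one concentration tested. For the compounds shown here, with thiophen-3-yl held constant, the first readable comparison at the ester shows pentan-3-yl in place of tert-butyl on the oxygen next to a carbonyl group, giving a number 5 percentage points higher from compound 1 to compound 3 (within the scatter), and this exchange is likewise not separated from the scatter. No independent data bear on these results, so neither step can be tied to any explanation.

As far as these compounds go, all three compounds remain close to the floor of the read-out, so it stays open whether the thiophene attachment point or the choice of ester group would matter in a compound with clear displacement. Also open, from the compounds shown here alone, is what a phenyl ring carrying a methoxy group on the saturated ring carbon, or a longer chain such as hexyl on the ester oxygen, would do to the reading in this assay at the same concentration.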